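This account rests on a few compounds, and the source may have more. Where it says the series, first, only, none or still open, it means among the compounds named here.

Measured so far in a functional assay on DU-145 cells (Homo sapiens) for antiproliferative activity, read by sulforhodamine B assay, with a stated time of 3 days; a higher number here means a weaker inhibitor of growth, a lower number a stronger inhibitor of growth:
compound 1 `O=C(Nc1nccs1)c1cccc(Nc2ncc(F)c(Nc3ccc(F)cc3)n2)c1`: > 10000 nM (a limit, not a number)
compound 2 `O=C(Nc1cccc(Nc2ncc(F)c(Nc3ccc(F)cc3)n2)c1)c1cnccn1`: 26400 nM
compound 3 `O=C(c1cccc(Nc2ncc(F)c(Nc3ccc(F)cc3)n2)c1)N1CCCCC1`: 13000 nM

Compound 3 has the lower of the two readable numbers in this assay. Among the measured compounds shown here, the only other reading is the limit of compound 1.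

Compound 4 `O=C(Nc1cc(Cl)cc(Cl)c1)c1cccc(Nc2ncc(F)c(Nc3ccc(F)cc3)n2)c1` is not yet measured. It carries (3,5-dichlorophenyl)amino in place of piperidin-1-yl on a carbonyl carbon.

For the measured compounds named here, the only step of readable size is a 2.0-fold lower number from compound 2 to compound 3 (0.31 log units; beyond the scatter), and it is modest. The measured change at the same carbonyl carbon is a step that the limit leaves unreadable from compound 1 to compound 3, so it offers no size and no direction for the reverse kind of swap, an amino group replacing piperidin-1-yl. Going by the values given here, the series therefore supports no large step, and only a weak lean towards a lower number. A result reported only as a limit remains quite possible.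

The expected step is a 1.3-fold lower number from compound 3 to compound 4 (0.11 log units; within the scatter), with no clear move beyond the scatter anticipated.

Compound 4 is estimated at 10000 nM, with an expected range of 3000 nM to 30000 nM.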

Compound 4, concentration for 50% growth inhibition: 17500 nM
Estimate against measurement, compound 4: 1.8-fold (0.24 log units) below; low and high end bracket the measured number.
By their numbers in this assay, from the lowest: compounds 3, 4 and 2 (each within the scatter of the next, the first and the last beyond it).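

At the carbonyl carbon, (3,5-dichlorophenyl)amino brings an aromatic ring and a hydrogen-bond donor in place of the non-aromatic piperidin-1-yl, yet this assay separates the two amides by no more than the scatter, with a 1.3-fold higher number from compound 3 to compound 4 (0.13 log units; within the scatter). The comparison with the pyrazine amide is just as flat, with a 1.5-fold lower number from compound 2 to compound 4 (0.18 log units; within the scatter), so (3,5-dichlorophenyl)carbamoyl gives no readable gain over ((pyrazin-2-yl)carbonyl)amino on the aromatic carbon. Compound 1 is recorded only as a limit, and no step involving it can be read: the limit of > 10000 nM in this assay, at which 1 of the 4 values shown sits.

Still open, on these data alone, is whether a side chain carrying an amine, such as 2-(dimethylamino)ethylamino, or a carboxylic acid at this carbonyl carbon would move the number beyond the scatter of these values. The compounds shown also leave open whether any change at this carbonyl carbon alone can do so.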